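The compounds below may be only part of what the source reports. "The series", "measured", "known", "first", "only" and "open" are said of these compounds alone.

Compound 1 `COc1cc(-c2nc(-c3ccccc3)[nH]c2-c2ccnc(NCCCNS(=O)(=O)c3ccccc3)n2)ccc1F`: 4520 nM
Compound 2 `COc1cc(-c2nc(-c3ccccc3)[nH]c2-c2ccnc(NCCCNS(=O)(=O)c3ccc(Br)cc3)n2)ccc1F`: 33900 nM
Compound 3 `COc1cc(-c2nc(-c3ccccc3)[nH]c2-c2ccnc(NCCCNS(=O)(=O)c3cccc4ccccc34)n2)ccc1F`: 14900 nM

These values come from a functional assay on LOX IMVI cells (Homo sapiens) for cytotoxicity, read by MTT assay, with a stated time of 24 h (on this read-out higher numbers stand for weaker inhibition and lower numbers for stronger inhibition), where compound 1 has the lowest number of the three. Compound 4 `O=S(=O)(NCCCNc1nccc(-c2[nH]c(-c3ccccc3)nc2-c2ccc(Cl)c(O)c2)n1)c1ccccc1` has not yet been measured. It carries 4-chloro-3-hydroxyphenyl in place of 4-fluoro-3-methoxyphenyl on an aromatic carbon of the core: 4-chloro-3-hydroxyphenyl in place of 4-fluoro-3-methoxyphenyl on an aromatic carbon.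

Within the data shown here, no measured step changes this place, so none predicts the direction. The nearest guides are changes at the other end of the molecule. Bromo in place of hydrogen on an aromatic carbon gave a 7.5-fold higher number from compound 1 to compound 2 (0.88 log units; beyond the scatter), and naphthalen-1-yl in place of phenyl on a sulfonyl sulfur gave a 3.3-fold higher number from compound 1 to compound 3 (0.52 log units; beyond the scatter). Both steps are modest, which suggests how far one change has moved the number among these compounds. A step of similar modest size is therefore expected to be possible, in either direction. The expected central change is a 1.0-fold lower number from compound 1 to compound 4 (0.00 log units; within the scatter). For compound 4 the estimated value is 4500 nM, with an expected range of 1400 nM to 15000 nM.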

Compound 4, half-maximal inhibitory concentration: 2630 nM
The estimate for compound 4 lay 1.7-fold (0.23 log units) above the measured number; the range from low to high includes it.
By their numbers in this assay, from the lowest: compounds 4 and 1 (each within the scatter of the next); then compound 3; then compound 2.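

In this assay, placing 4-chloro-3-hydroxyphenyl where compound 1 carries 4-fluoro-3-methoxyphenyl gave a 1.7-fold lower number from compound 1 to compound 4 (0.24 log units; within the scatter), so this change on the core left the number within the usual scatter, whereas both measured changes at the sulfonyl end moved it beyond the scatter. The entering group differs in two ways at once, with chloro replacing fluoro and hydroxy replacing methoxy, and it brings a hydrogen-bond donor that the leaving group lacks, yet this combined change produced no clear shift. Nothing here explains why the number held.

On these data alone, because the two replacements arrive together, their separate contributions remain unknown, and they could be large and opposing or both small. As far as these compounds go, it also remains open whether an amine or a carboxylic acid in place of the hydroxy group would be accommodated as well.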